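The source may report more compounds than this note shows. Statements on the series, on what has been measured and on what is new or still open speak of the compounds shown alone.

Measured in a functional assay for inhibition, with Homo sapiens as the target; a lower number here means a stronger inhibitor, a higher number a weaker inhibitor:
- compound 1 `CCC1(O)CS(=O)(=O)c2cc(C(=O)N=C(N)N)c(C)cc21`: 77 nM
- compound 2 `CCC1CS(=O)(=O)c2cc(C(=O)N=C(N)N)c(C)cc21`: 78 nM
- compound 3 `Cc1cc2c(cc1C(=O)N=C(N)N)S(=O)(=O)C(C)(C)C2=O`: 354 nM

Compound 2, at 78 nM, lies within the scatter of compound 1, while compound 3 carries the higher number at 354 nM. The account now follows the change to compound 4 `Cc1cc2c(cc1C(=O)N=C(N)N)S(=O)(=O)CC2`, which has hydrogen in place of ethyl on a saturated ring carbon.

Within the data shown here, only one measured step involves that ring carbon: a 1.0-fold higher number from compound 1 to compound 2 (0.01 log units; within the scatter), with hydrogen in place of hydroxy. Among the measured compounds shown here, it is a different exchange, and no measured step removes the ethyl. Compound 3 differs from compound 2 in more than one place, so it gives no size for this change.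

The evidence is therefore thin. Resting on the small step of a 1.0-fold higher number from compound 1 to compound 2 (0.01 log units; within the scatter), a change no larger than the scatter is expected in this assay, leaning cautiously towards a higher number. The expected size is a 1.4-fold higher number from compound 2 to compound 4 (0.15 log units; within the scatter). For compound 4 the estimated value is 110 nM, with an expected range from 40 nM to 300 nM.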

Compound 4, half-maximal inhibitory concentration: 587 nM
Compound 4: middle estimate off by 5.3-fold (0.73 log units), on the low side; the measured number lies above the stated range.
By their numbers in this assay, from the lowest: compounds 1 and 2 (each within the scatter of the next); then compounds 3 and 4 (each within the scatter of the next).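

In this assay, among these compounds, the step of a 7.5-fold higher number from compound 2 to compound 4 (0.88 log units; beyond the scatter) is the first measured change at this saturated ring carbon that lies beyond the scatter. The earlier exchange at the same carbon, the step of a 1.0-fold higher number from compound 1 to compound 2 (0.01 log units; within the scatter) with hydrogen in place of hydroxy, kept the ethyl and stayed within the scatter, so among these compounds only the loss of ethyl moves the number beyond the scatter. Nothing shown here gives a measured reason for the size of this step.

On these data alone, with only ethyl and hydrogen compared directly at this carbon, it remains open whether a methyl would give a number closer to that of compound 2 or of compound 4. As far as these compounds go, it also remains open how a longer chain such as propyl, or an amine, would behave in the same place.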